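Nitro in Place of Methoxy on the Benzyl Ring

The compounds below may be only part of what the source reports. "The series", "measured", "known", "first", "only" and "open" are said of these compounds alone.

Three compounds share one core and differ only in the aromatic ring joined through a saturated chain carbon to an amine nitrogen in a ring. In a functional assay on the whole organism for antagonist activity, with Mus musculus as the target (on this read-out lower numbers stand for an effect already at smaller amounts and higher numbers for an effect only at larger amounts of compound), compound 3 `COc1ccc(CN2CCC(C(=O)Nc3cc(Cl)c(N)cc3OC)CC2)cc1` gives 0.9 mg/kg, the lowest of the three numbers. Compound 1 `COc1cc(N)c(Cl)cc1NC(=O)C1CCN(Cc2cccc(C)c2)CC1` gives 2.4 mg/kg in this assay, and compound 2 `CCOc1ccc(CN2CCC(C(=O)Nc3cc(Cl)c(N)cc3OC)CC2)cc1` gives 6.3 mg/kg. The steps between them are a 2.7-fold lower number from compound 1 to compound 3 (0.43 log units; beyond the scatter) and a 7.0-fold lower number from compound 2 to compound 3 (0.85 log units; beyond the scatter), both beyond the scatter, so changing the group on that ring plainly moves the number. Compound 4 `COc1cc(N)c(Cl)cc1NC(=O)C1CCN(Cc2ccc([N+](=O)[O-])cc2)CC1` carries the change (nitro in place of methoxy on an aromatic carbon). Among the compounds with values here, no measured step involves a nitro group, so the only guidance is that compound 3 sits at the low end and that the two substitutions away from it, a 2.7-fold lower number from compound 1 to compound 3 (0.43 log units; beyond the scatter) and a 7.0-fold lower number from compound 2 to compound 3 (0.85 log units; beyond the scatter), both went the other way. On that basis a modest rise is expected, a 2.8-fold higher number from compound 3 to compound 4 (0.44 log units; beyond the scatter). Compound 4 is therefore estimated at 2.5 mg/kg in this assay, with a range from 0.7 mg/kg to 9 mg/kg.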

Compound 4, dose for half-maximal effect: > 4 mg/kg
Compound 4: only a limit was reported; the forecaster's own chance of this, stated with the estimate: 10%; middle value at least 1.6-fold (0.20 log units) from the limit.
By their numbers in this assay, from the lowest: compound 3; then compound 1; then compound 2.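

In this assay, compound 4 is reported only as a limit, > 4 mg/kg. Even so, nitro in place of methoxy at this place, para to a large group, gives an at least 4.4-fold higher number from compound 3 to compound 4 (0.64 log units; beyond the scatter), so methoxy now compares favourably with two other groups at this position, ethoxy and nitro, and compound 3 keeps the lowest number of the four. Against the meta-free comparison with the 3-methylphenyl compound the picture is less clear: the result is an at least 1.6-fold higher number from compound 1 to compound 4 (0.22 log units; that floor lies within the scatter), a floor that does not by itself separate the two, and the step between compound 2 and compound 4 cannot be read.

From the compounds shown here alone, how far compound 4 really lies past its limit stays open. Also open, going by these compounds, is whether an amine, a hydroxyl or a single fluorine at this place would give a number lower than that of compound 3.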